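This account rests on a few compounds, and the source may have more. Where it says the series, first, only, none or still open, it means among the compounds named here.

Measured so far in an ADME assay on L02 cells (Homo sapiens) for antiproliferative activity, read by MTT assay, with a stated time of 48 h; a lower number here means a stronger inhibitor, a higher number a weaker inhibitor:
compound 1, `N#CC1=C(N)Oc2c(c3nc4ccccc4nc3c3ccccc23)C12C(=O)N(Cc1cnnn1-c1ccccc1Cl)c1ccccc12`: > 50000 nM, a limit of the assay rather than a number.
compound 2, `COc1ccccc1-n1nncc1CN1C(=O)C2(C(C#N)=C(N)Oc3c2c2nc4ccccc4nc2c2ccccc32)c2ccccc21`: > 50000 nM, likewise a limit.
compound 3, `Cc1cc(C)cc(-n2nncc2CN2C(=O)C3(C(C#N)=C(N)Oc4c3c3nc5ccccc5nc3c3ccccc43)c3ccccc32)c1`: > 50000 nM, likewise a limit.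

Compound 1 stands nowhere in particular on the numbers shown: its value is a limit, and the same holds for its two companions, so that all three sit at the limit of > 50000 nM in this assay, at which 3 of the 3 values shown sit. The steps a step that the two limits leave unreadable from compound 1 to compound 2 and a step that the two limits leave unreadable from compound 1 to compound 3 cannot be read for size, nor can a step that the two limits leave unreadable from compound 2 to compound 3; each joins two limits. Compound 4, `Cc1ccc(-n2nncc2CN2C(=O)C3(C(C#N)=C(N)Oc4c3c3nc5ccccc5nc3c3ccccc43)c3ccccc32)cc1Cl`, differs from compound 1 in one place: 3-chloro-4-methylphenyl in place of 2-chlorophenyl on an aromatic nitrogen. The three steps just named are the ones that bear on this change, and every one of them is unreadable because both of its ends sit at the limit of > 50000 nM in this assay, at which 3 of the 3 values shown sit. No size can therefore be expected for a step that the limit leaves unreadable from compound 1 to compound 4 beyond the expectation that compound 4 stays at the limit too, given that compound 2 and compound 3 both rest at the limit of > 50000 nM in this assay, at which 3 of the 3 values shown sit. Compound 4 is estimated at 60000 nM, with a range from 30000 nM to 150000 nM, and is expected most likely to be reported again as a limit.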

Compound 4, half-maximal inhibitory concentration: > 50000 nM
Compound 4 was reported as a limit; the forecaster's own chance of this, stated with the estimate: 85%; the middle value is on the limit's open side.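

No new step can be read in this assay: compound 4 joins compound 1, compound 2 and compound 3 only through pairs of limits, and the size of each step stays unreadable: the limit of > 50000 nM in this assay, at which 4 of the 4 values shown sit.

The compounds shown leave open how far each of the four lies past the limit, and whether any group on the aromatic nitrogen gives a measurable value.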